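Swapping sec-butyl for 2-methoxyethyl on a shared core

The compounds below may be only part of what the source reports. "The series", "measured", "known", "first", "only" and "open" are said of these compounds alone.

Of the compounds shown here, three with the same core have been tested in a functional assay (Nicotiana tabacum); a higher number here means a weaker inhibitor, a lower number a stronger inhibitor. They differ in the group on a nitrogen on an aromatic ring. Compound 1 `CNc1nc(SC)nc2ncccc12`, with methyl there, gives 2920 nM. Compound 2 `CCCCCNc1nc(SC)nc2ncccc12`, with pentyl, gives 650 nM, and compound 3 `CCC(C)Nc1nc(SC)nc2ncccc12`, with sec-butyl, gives 860 nM.

Compound 3 stands close to compound 2, as the small gap shows: a 1.3-fold higher number from compound 2 to compound 3 (0.12 log units; within the scatter). Its distance from compound 1 is clear: a 3.4-fold lower number from compound 1 to compound 3 (0.53 log units; beyond the scatter). The pentyl chain gives a similar picture: a 4.5-fold lower number from compound 1 to compound 2 (0.65 log units; beyond the scatter).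

Compound 4 `COCCNc1nc(SC)nc2ncccc12` has not yet been measured. The change is 2-methoxyethyl in place of sec-butyl on a nitrogen on an aromatic ring, which means 2-methoxyethyl in place of sec-butyl on a nitrogen on an aromatic ring. For the measured compounds named here, no measured compound carries this group, so the measured steps bear on it only indirectly. They show a modest range, from methyl in compound 1 at one end to pentyl and sec-butyl at the other. Compound 4 is therefore expected to fall inside that range, nearer compound 3. The expected move in this assay is a small one towards a higher number: a 1.6-fold higher number from compound 3 to compound 4 (0.21 log units; within the scatter). For compound 4 the estimated value is 1400 nM, within an expected range from 600 nM to 3300 nM.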

Compound 4, half-maximal inhibitory concentration: 2530 nM
Beside the measured number, compound 4's estimate is 1.8-fold (0.26 log units) below it, within the range that was stated.
By their numbers in this assay, from the lowest: compounds 2 and 3 (each within the scatter of the next); then compounds 4 and 1 (each within the scatter of the next).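

In this assay, this nitrogen does not treat two similar-sized groups alike: replacing sec-butyl with 2-methoxyethyl gives a 2.9-fold higher number from compound 3 to compound 4 (0.47 log units; beyond the scatter) even though both groups have 4 heavy atoms and no ring, and they differ mainly in that one chain carbon gives way to an oxygen that counts as a hydrogen-bond acceptor. The same loss appears against the pentyl chain, with a 3.9-fold higher number from compound 2 to compound 4 (0.59 log units; beyond the scatter) as the step, whereas the comparison with the small methyl group shows a 1.2-fold lower number from compound 1 to compound 4 (0.06 log units; within the scatter) and so no real difference, which means that among these four compounds a group larger than methyl does not by itself bring a lower number. Compound 4 is the exception to the link between larger groups and lower numbers that compounds 1, 2 and 3 had suggested, and no measurement shown explains why.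

The compounds shown leave open whether the oxygen matters through its presence or through where it sits in the chain. A 3-methoxypropyl chain, a 2-hydroxyethyl chain or a chain ending in an amine would help to separate these possibilities.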